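Swapping bromo for chloro on a shared thiourea core

A few compounds are considered here, and "the series" means these few. Any claim that something is new, unique, unknown or untested is made for them only; others in the source may bear on it.

Three compounds share a quinazoline-type core with a sulfonamide-bearing aryl group, and all were tested in a functional assay on A-431 cells (Homo sapiens) for antiproliferative activity, read by MTT assay, with a stated time of 72 h; on this read-out higher numbers stand for weaker inhibition and lower numbers for stronger inhibition. Compound 1 `COc1cc2ncnc(Nc3ccc(Cl)c(C(F)(F)F)c3)c2cc1OCCCCC(=O)Nc1ccc(S(N)(=O)=O)cc1` links the two parts through a pentanamide chain and gives 3910 nM. Compound 2 `NS(=O)(=O)c1ccc(NC(=S)Nc2ccc3ncnc(Nc4ccc(F)c(Br)c4)c3c2)cc1` uses a thiourea link instead and gives 18200 nM. Compound 3 `NS(=O)(=O)c1ccc(NC(=S)Nc2ccc3ncnc(Nc4cccc(Br)c4)c3c2)cc1` keeps that thiourea link and gives 20700 nM. Compound 3 thus shows the highest number of the three, but the single-point step a 1.1-fold higher number from compound 2 to compound 3 (0.06 log units; within the scatter) is within the scatter, whereas the lower number of compound 1 lies beyond it.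

Compound 4 `NS(=O)(=O)c1ccc(NC(=S)Nc2ccc3ncnc(Nc4cccc(Cl)c4)c3c2)cc1` differs from compound 3 in one place only: chloro in place of bromo on an aromatic carbon. Among the measured compounds shown here, no measured pair shows this exact exchange. For the measured compounds named here, the only single-point step available, a 1.1-fold higher number from compound 2 to compound 3 (0.06 log units; within the scatter), removes a fluoro and changes nothing beyond the scatter, and it does not involve the bromo position. With no evidence of a large effect from a halogen exchange at this position, the step from compound 3 to compound 4 is expected to be small, about a 1.0-fold lower number from compound 3 to compound 4 (0.01 log units; within the scatter), with no clear direction. Compound 4 is therefore estimated at 20000 nM, with a likely range from 8000 nM to 50000 nM.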

Compound 4, half-maximal inhibitory concentration: 15000 nM
For compound 4 the middle estimate is 1.3-fold (0.12 log units) above the measured one; low and high end bracket the measured number.
By their numbers in this assay, from the lowest: compound 1; then compounds 4, 2 and 3 (each within the scatter of the next).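

Swapping 3-bromophenyl for 3-chlorophenyl gives a 1.4-fold lower number from compound 3 to compound 4 (0.14 log units; within the scatter) and offers the first direct look at changing the halogen at this place on the shared core: the heavier and lighter halogen cannot be told apart on this read-out. The broader change, which replaces 3-bromo-4-fluorophenyl with 3-chlorophenyl, gives a 1.2-fold lower number from compound 2 to compound 4 (0.08 log units; within the scatter) and likewise leaves the number within ordinary measurement variation, so compound 2, compound 3 and compound 4 cannot be ranked against one another. No measurement available here explains why these halogen changes leave the result so flat.

It remains open whether a group of a different kind at this place on the ring, such as an amine or a carboxylic acid, would move the number beyond the scatter, since every substituent shown at this place is a halogen. As far as these compounds go, compound 1 differs from these thiourea compounds in several places at once, so the effect of its pentanamide chain remains open and would need a partner compound that differs from it in that chain alone.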